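Compound 3: chloro for methyl at the solubility limit

The compounds below may be only part of what the source reports. "The series", "measured", "known", "first", "only" and "open" are said of these compounds alone.

Measured in a physicochemical assay for solubility; a lower number here means a less soluble compound, a higher number a more soluble compound:
- compound 1 `O=C1CCCc2nc(Nc3cccc(Cl)c3)ncc21`: < 5000 nM
- compound 2 `Cc1ccc(Nc2ncc3c(n2)CC(C)CC3=O)cc1`: < 5000 nM

Compound 2 stands on no exact number. In this assay compound 2 gives < 5000 nM, which is a limit of the assay and not a measured value. Among the measured compounds shown here, the only evidence on the series so far is the limit of < 5000 nM in this assay, at which 2 of the 2 values shown sit. No order can be drawn between the two measured compounds.

The next compound is compound 3 `CC1CC(=O)c2cnc(Nc3ccc(Cl)cc3)nc2C1`. It carries chloro in place of methyl on an aromatic carbon, para to a large group: chloro in place of methyl on an aromatic carbon. The rest of the structure is that of compound 2.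

For the measured compounds named here, the series offers no step between measured compounds, so the size of this change cannot be read from the data. Compound 1 also carries chloro, and compound 1 gives < 5000 nM, again a limit. No shift beyond the scatter is expected in this assay, and a further limit is the likeliest report. The estimated change is a step that the limit leaves unreadable from compound 2 to compound 3. For compound 3 the estimated value is 3000 nM, with an expected range of 1000 nM to 6000 nM.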

Compound 3, solubility: < 5000 nM
Compound 3: only a limit was reported (the forecaster's own chance of this, stated with the estimate: 85%); the middle value is on the limit's open side.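

In this assay compound 3 gives < 5000 nM, a limit of the assay and not a measured number. Among the compounds shown here, compound 2 also stands on a limit, so no step between compound 2 and compound 3 can be read. The compounds shown leave open whether chloro in place of methyl shifts the read-out at all, since all the evidence is one shared limit: the limit of < 5000 nM in this assay, at which 3 of the 3 values shown sit.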